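Fixing the ring stereocentre: compound 3 to compound 4

The source may report more compounds than this note shows. Statements on the series, on what has been measured and on what is new or still open speak of the compounds shown alone.

Three compounds sharing one core differ only in the group attached to an aromatic carbon. Compound 1 `CC(C(=O)NCc1ccc(C(F)(F)F)nc1CCC(C)(C)C)c1ccc(NS(C)(=O)=O)c(F)c1` gives 0.6 nM in an assay on CHO cells for antagonist activity at transient receptor potential cation channel subfamily V member 1 (Homo sapiens), read by FLIPR and calcium flux; a higher number here means a weaker inhibitor, a lower number a stronger inhibitor. Compound 2 `CC(C(=O)NCc1ccc(C(F)(F)F)nc1C1CC2CCC1C2)c1ccc(NS(C)(=O)=O)c(F)c1` gives 1.5 nM, and compound 3 `CC1C=C(c2nc(C(F)(F)F)ccc2CNC(=O)C(C)c2ccc(NS(C)(=O)=O)c(F)c2)CCC1` gives 0.2 nM. Compound 3 shows the lowest number of the three: the step is a 3.0-fold lower number from compound 1 to compound 3 (0.48 log units; beyond the scatter) and a 7.5-fold lower number from compound 2 to compound 3 (0.88 log units; beyond the scatter), while a 2.5-fold higher number from compound 1 to compound 2 (0.40 log units; beyond the scatter) runs the other way.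

Compound 4 `CC(C(=O)NCc1ccc(C(F)(F)F)nc1C1=C[C@H](C)CCC1)c1ccc(NS(C)(=O)=O)c(F)c1` keeps every atom and bond of compound 3; the change is the two compounds have the same atoms and bonds; at least one stereo element is drawn with a configuration in one of them and without one in the other: 1 of 2 stereo elements differ; a stereocentre at a saturated ring carbon is drawn without a configuration in compound 3 and R in compound 4. Compound 3 is therefore drawn as a mixture at that centre, and compound 4 is one of its two forms. For the measured compounds named here, none of the measured steps concerns a stereo element; they all swap whole groups, so they offer no direct guide. A single form can match the mixture or differ from it in either direction. Compound 4 is expected to sit near compound 3, with the step of no change at the digits printed from compound 3 to compound 4 (within the scatter), giving an estimated 0.2 nM within a range of 0.07 nM to 0.6 nM.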

Compound 4, inhibition constant: 0.1 nM
Compound 4: middle estimate off by 2.0-fold (0.30 log units), on the high side, within the range that was stated.
By their numbers in this assay, from the lowest: compounds 4 and 3 (each within the scatter of the next); then compound 1; then compound 2.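

In this assay, for the compounds shown here, the step of a 2.0-fold lower number from compound 3 to compound 4 (0.30 log units; within the scatter) puts the single R form level with the mixture, something the earlier steps could not show, since they all swapped whole groups. The gaps to the other groups also hold for the single form, with a 6.0-fold lower number from compound 1 to compound 4 (0.78 log units; beyond the scatter) and a 15-fold lower number from compound 2 to compound 4 (1.18 log units; beyond the scatter) both beyond the scatter. The reading of this pair as a single form against a mixture rests on one fact: the fact that one of compounds 3 and 4 is drawn with a defined configuration and the other without, at the place where they differ

Still open, as far as these compounds go, is how the S form at this ring carbon would compare with the R form, since the mixture alone cannot settle that. Also open, from the compounds shown here alone, is whether an ethyl group in place of the ring methyl, or a hydroxyl group on the ring, would hold the number this low.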